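The compounds below may be only part of what the source reports. "The series", "measured", "known", "first", "only" and "open" are said of these compounds alone.

Measured so far:
compound 1 `CCCCCCCCCCCCCCNC(=O)[C@@H](NC(=O)c1cccs1)[C@@H](C)O` — 88400 nM
compound 2 `CCCCCCCCCCCCCCNC(=O)[C@@H](NC(=O)c1cc2ccccc2[nH]1)[C@@H](C)O` — 10500 nM

Both compounds share a core carrying a long chain amide and an aminoalcohol unit; they differ only in the ring attached to the carbonyl carbon of the second amide. Within the data shown here, in a functional assay on HepG2 cells (Homo sapiens) for cytotoxicity, read by MTT assay, with a stated time of 48 h (a lower number here means a stronger inhibitor, a higher number a weaker inhibitor), compound 2 gives the lowest of the two numbers, and the only step measured so far, an 8.4-fold lower number from compound 1 to compound 2 (0.93 log units; beyond the scatter), shows that swapping a thiophene ring for an indole ring made the compound a noticeably stronger inhibitor.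

Compound 3 `CCCCCCCCCCCCCCNC(=O)[C@@H](NC(=O)/C=C/c1ccccc1)[C@@H](C)O` is the next candidate. Its change from compound 2 is 2-phenylethenyl in place of 1H-indol-2-yl on a carbonyl carbon. Among the measured compounds shown here, the one step measured bears on this only loosely: it shows that the group on this carbonyl carbon matters, but neither of its two groups is the 2-phenylethenyl now entering. The step from compound 2 to compound 3 is therefore expected to move back toward a higher number, a 2.9-fold higher number from compound 2 to compound 3 (0.46 log units; beyond the scatter), as a guess with wide uncertainty. For compound 3 the estimate in this assay is 30000 nM, within a range from 8000 nM to 100000 nM.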

Compound 3, half-maximal inhibitory concentration: 150000 nM
Compound 3: middle estimate off by 5.0-fold (0.70 log units), on the low side, outside the stated range (above it).
By their numbers in this assay, from the lowest: compound 2; then compounds 1 and 3 (each within the scatter of the next).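

The new result shows that the gain seen with 1H-indol-2-yl does not extend to every larger aromatic group on this carbonyl carbon: in this assay, the change to 2-phenylethenyl gives a 14-fold higher number from compound 2 to compound 3 (1.15 log units; beyond the scatter) and so loses the advantage of compound 2. Thiophen-2-yl and 2-phenylethenyl, though very different in structure, cannot be told apart here, with a 1.7-fold higher number from compound 1 to compound 3 (0.23 log units; within the scatter), so among these three compounds only the 1H-indol-2-yl group of compound 2 stands out. Nothing available explains why this group differs from the other two.

The change from compound 2 to compound 3 removes the ring nitrogen with its hydrogen-bond donor, opens the five-membered ring and adds a double bond outside the aromatic rings all at once, so these three compounds cannot show which of these differences counts. A 1H-indol-2-yl group carrying a methyl on its ring nitrogen, or a plain phenyl on the same carbonyl carbon, would begin to separate these possibilities.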